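Cytotoxicity notes: removing the aryl methyl across the series

The source may hold more compounds than are shown below. What is called first, only, known or untested is meant among the compounds shown, and "the series" means these compounds.

Three members of the series carry a measurement in an ADME assay on MT4 cells (Homo sapiens) for cytotoxicity, read by MTT assay, with a stated time of 96 h; on this read-out higher numbers stand for lower toxicity in this test and lower numbers for higher toxicity in this test. Compound 1 `Cc1ccc(NCc2cn(-c3ccccc3)nc2-c2ccc(Br)cc2)cc1` sits at a limit in this assay, > 100000 nM. Compound 2 `Cc1ccc(-c2nn(-c3ccccc3)cc2CNc2ccc(Cl)cc2)cc1` also returns only a limit in this assay, > 100000 nM. Compound 3 `Brc1ccc(-c2nn(-c3ccccc3)cc2CNc2ccccc2)cc1` likewise gives a limit in this assay, > 100000 nM. The difference between the cores of compound 1 and compound 2 is not broken down here. From compound 1 to compound 3 the change is hydrogen in place of methyl on an aromatic carbon, and the size of that step in this assay is a step that the two limits leave unreadable from compound 1 to compound 3. Compound 4 `Clc1ccc(NCc2cn(-c3ccccc3)nc2-c2ccccc2)cc1` is not yet measured; it differs from compound 2 by hydrogen in place of methyl on an aromatic carbon, the same change at the same place as before. Among the measured compounds shown here, the step expected in this assay from compound 2 to compound 4 is a number no higher from compound 2 to compound 4 (the limit leaves the size open), resting on (the limit of > 100000 nM in this assay, at which 3 of the 3 values shown sit), where every value so far sits, and on the unreadable earlier step. For compound 4 the estimate in this assay is 100000 nM, most likely reported again only as a limit, with an expected range of 50000 nM to 300000 nM.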

Compound 4, half-maximal cytotoxic concentration: > 100000 nM
Compound 4: no number, only a limit (the forecaster's own chance of this, stated with the estimate: 85%); the middle value lies on the limit itself.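

Compound 4 also gives only a limit in this assay, > 100000 nM. With compound 2 at a limit too, no step can be read between compound 2 and compound 4. The compounds shown leave open whether hydrogen in place of methyl changes the read-out at all, and at what concentration cytotoxicity would appear in this assay: the limit of > 100000 nM in this assay, at which 4 of the 4 values shown sit.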